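Piperidine diphenylmethyl carbamates: hydroxy to fluoro on the aryl ring

This account rests on a few compounds, and the source may have more. Where it says the series, first, only, none or still open, it means among the compounds named here.

Measured so far in an assay on isolated protein for inhibition of Fatty-acid amide hydrolase 1 (Rattus norvegicus), read by fluorescence; a lower number here means a stronger inhibitor, a higher number a weaker inhibitor:
compound 1 `N#Cc1cccc(OC(=O)N2CCC(S(=O)(=O)C(c3ccccc3)c3ccccc3)CC2)c1`: "not determined" (no result reported)
compound 2 `N#Cc1cccc(OC(=O)N2CCC(OC(c3ccccc3)c3ccccc3)CC2)c1`: > 1000 nM
compound 3 `N#Cc1cc(O)cc(OC(=O)N2CCC(C(c3ccccc3)c3ccccc3)CC2)c1`: > 1000 nM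

Compound 2 shows in this assay only a limit of the assay, > 1000 nM. Compound 3 likewise shows only a limit, > 1000 nM. For compound 1 no value is available. Compound 3 therefore sits at the limit of > 1000 nM in this assay, at which 2 of the 3 values shown sit, with no numerical ranking possible among the three.

Going by the values given here, no pair of measured compounds differs in a single place, so no measured step size exists. Compound 4 `N#Cc1ccc(F)c(OC(=O)N2CCC(C(c3ccccc3)c3ccccc3)CC2)c1` carries 5-cyano-2-fluorophenyl in place of 3-cyano-5-hydroxyphenyl on an oxygen next to a carbonyl group. The change is expected to give a moderately stronger compound in this assay; the expected step is an at least 2.0-fold lower number from compound 3 to compound 4 (0.30 log units; that floor lies within the scatter), but with wide uncertainty. Compound 4 is estimated at 500 nM, in a range from 60 nM to 4000 nM.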

Compound 4, half-maximal inhibitory concentration: > 1000 nM
Compound 4 gave a limit, no number; the forecaster's own chance of this, stated with the estimate: 35%; middle value at least 2.0-fold (0.30 log units) from the limit.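

Compound 3 and compound 4 both give only limits, so no step between them can be read: the limit of > 1000 nM in this assay, at which 3 of the 4 values shown sit.

The compounds shown leave open whether 5-cyano-2-fluorophenyl in place of 3-cyano-5-hydroxyphenyl changes inhibition at all.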